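The source may hold more compounds than are shown below. What is called first, only, known or untested is meant among the compounds shown, and "the series" means these compounds.

Measured so far:

Compound 1 `Cc1noc(C)c1-c1cnc(N)c(Oc2ccc(C(=O)Nc3cc(Cl)ccn3)cc2)n1`: in a functional assay on HepG2 cells (Homo sapiens) for inhibition, read by MTT assay, with a stated time of 72 h (on this read-out higher numbers stand for weaker inhibition and lower numbers for stronger inhibition), compound 1 gives > 100000 nM, a limit of the assay.
Compound 2 `Cn1cc(-c2cnc(N)c(Oc3ccc(C(=O)Nc4cccc(Cl)c4)cc3)n2)cn1`: in this assay compound 2 gives 21200 nM.
Compound 3 `Cc1noc(C)c1-c1cnc(N)c(NCc2ccc(C(=O)Nc3ccc(Cl)cc3)cc2)n1`: in this assay compound 3 gives > 100000 nM, again a limit of the assay.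

Compound 3 thus stands at the limit, and the limit of > 100000 nM in this assay, at which 2 of the 3 values shown sit, marks where it sits together with compound 1. Among the measured compounds shown here, the only full number in the set belongs to compound 2, which carries the 1-methyl-1H-pyrazol-4-yl group; compound 1 and compound 3, both at the limit, carry the 3,5-dimethyl-1,2-oxazol-4-yl group. For the measured compounds named here, no pair differing in one place has been measured, so no step size can be read from the data.

Compound 4 `Cn1cc(-c2cnc(N)c(NCc3ccc(C(=O)Nc4ccc(Cl)cc4)cc3)n2)cn1` is the not yet measured partner of compound 3; the change is 1-methyl-1H-pyrazol-4-yl in place of 3,5-dimethyl-1,2-oxazol-4-yl on an aromatic carbon. Since compound 2 with the same entering group gives a number while compound 3 gives a limit, a move toward stronger inhibition is expected, but its size is uncertain and may stay within the scatter; the expected step is an at least 1.4-fold lower number from compound 3 to compound 4 (0.15 log units; that floor lies within the scatter). Compound 4 is expected to give about 70000 nM, with a range from 20000 nM to 200000 nM.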

Compound 4, half-maximal inhibitory concentration: 20100 nM
Compound 4: middle estimate off by 3.5-fold (0.54 log units), on the high side, and the stated range covers the measured number.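

Notes on the position para to an amino group, in this assay: replacing 3,5-dimethyl-1,2-oxazol-4-yl with 1-methyl-1H-pyrazol-4-yl on this aromatic carbon gives the first step readable in the series, an at least 4.9-fold lower number from compound 3 to compound 4 (0.69 log units; beyond the scatter). The two groups have the same counts of hydrogen-bond donors and acceptors, and each is a five-membered aromatic ring with 2 hetero atoms, so those features alone do not separate them. The step is only a floor because compound 3 stands at a limit of the assay: the limit of > 100000 nM in this assay, at which 2 of the 4 values shown sit.

As far as these compounds go, the full size of the step remains open. Also open, from the compounds shown here alone, is how a phenyl ring or a simple amine on this carbon would compare, and whether the same change gives a similar step with the other parts of the molecule altered.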